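The source may report more compounds than this note shows. Statements on the series, on what has been measured and on what is new or still open speak of the compounds shown alone.

Measured compounds:
Compound 1 `Cc1nc(C#Cc2cccc(F)c2)cs1` gives 23 nM in a functional assay on CHO cells for agonist activity at metabotropic glutamate receptor 5 (Homo sapiens), read by inositol phosphate accumulation; on this read-out lower numbers stand for stronger inhibition and higher numbers for weaker inhibition.
Compound 2 `COc1cccc(C#Cc2csc(C)n2)c1` gives 49 nM in this assay.
Compound 3 `Cc1nc(C#Cc2ccccc2F)cs1` gives 140 nM in this assay.

Among these three, compound 1 has the lowest number; compound 2 lies nearest to it and compound 3 furthest. Compound 4 `Cc1nc(C#Cc2cccc(C(F)(F)F)c2)cs1` differs from compound 1 by trifluoromethyl in place of fluoro on an aromatic carbon. Among the measured compounds shown here, the single measured step that bears on this exchange is the replacement of the same fluoro by another group on an aromatic carbon, a 2.1-fold higher number from compound 1 to compound 2 (0.33 log units; beyond the scatter), a modest rise. For the measured compounds named here, no measured step involves a trifluoromethyl. Compound 4 is therefore expected to show a modestly higher number than compound 1, a 1.7-fold higher number from compound 1 to compound 4 (0.24 log units; within the scatter). The estimate for compound 4 in this assay is 40 nM, with a range from 15 nM to 110 nM.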

Compound 4, half-maximal inhibitory concentration: 413 nM
Estimate against measurement, compound 4: 10-fold (1.01 log units) below; the measured number lies above the stated range.
By their numbers in this assay, from the lowest: compound 1; then compound 2; then compound 3; then compound 4.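

At this place on the six-membered aromatic ring, the number in this assay depends strongly on which group replaces fluoro: the trifluoromethyl exchange gives a large rise (an 18-fold higher number from compound 1 to compound 4 (1.25 log units; beyond the scatter)), whereas the earlier methoxy exchange gave only a modest one (a 2.1-fold higher number from compound 1 to compound 2 (0.33 log units; beyond the scatter)). Trifluoromethyl and methoxy also separate clearly from each other (an 8.4-fold higher number from compound 2 to compound 4 (0.93 log units; beyond the scatter)). Nothing available here accounts for these differences. The compounds shown leave open how a chloro, a methyl or a nitrile would fall at this same place, and whether an amine would follow methoxy or trifluoromethyl.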